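Methoxy Step on Two Carboxyphenyl Ether Variants

This account rests on a few compounds, and the source may have more. Where it says the series, first, only, none or still open, it means among the compounds named here.

Of the compounds shown here, three of one family have so far been tested in an ADME assay (liver) for metabolic stability, with Liver microsome (Rattus norvegicus) as the target, read by LC-MS, using microsomes and NADPH, with stated times of 5 min and 60 min, tested at 4 uM; a higher number here means that more of the compound is left, a lower number that less of the compound is left. Compound 2 `Cc1c(OCCCCOc2ccc(C(=O)O)cc2)ccc(C(=O)CC(C)C)c1O` gives 66%. Compound 1 `COc1cc(C(=O)O)ccc1OCCCCOc1ccc(C(=O)CC(C)C)c(O)c1C` gives 43%, and compound 3 `Cc1c(OCCCCOc2cccc(C(=O)O)c2)ccc(C(=O)CC(C)C)c1O` gives 51%. The values of compound 1 and compound 3 lie within the usual scatter of each other, so nothing separates them.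

Two changes tie the measured compounds together. From compound 2 to compound 1 the change is methoxy in place of hydrogen on an aromatic carbon, and it brought a number 23 percentage points lower from compound 2 to compound 1 (beyond the scatter). From compound 2 to compound 3 the change is 3-carboxyphenyl in place of 4-carboxyphenyl on an oxygen on a saturated carbon, which brought a number 15 percentage points lower from compound 2 to compound 3 (beyond the scatter).

Compound 4 `COc1ccc(C(=O)O)cc1OCCCCOc1ccc(C(=O)CC(C)C)c(O)c1C` has not yet been measured in this assay. It differs from compound 3 by methoxy in place of hydrogen on an aromatic carbon. Going by the values given here, this is the same kind of change as the one from compound 2 to compound 1, yet the surroundings differ: in compound 1 the entering methoxy sits meta to the carboxy group, in compound 4 it sits para to the carboxy group. Among the compounds with values here, only one measured step of this kind exists, so the comparison rests on a single pair.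

Compound 4 is expected to give 32% in this assay, with a likely range from 18% to 46%. Within the data shown here, the expected step, a number 19 percentage points lower from compound 3 to compound 4 (beyond the scatter), is sized to match the earlier one, because a number 23 percentage points lower from compound 2 to compound 1 (beyond the scatter) is the only measurement of this kind of change available.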

Compound 4, percent of the compound remaining: 5%
Compound 4: the middle estimate sits 27 percentage points above what was measured; measured number below the stated range.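

The methoxy step therefore carries over in direction but not in size. In this assay, methoxy in place of hydrogen on an aromatic carbon brought a number 46 percentage points lower from compound 3 to compound 4 (beyond the scatter), so less of the compound was left here too, but the loss was clearly larger than on the earlier core: the same change on two cores in this assay, a number 23 percentage points lower (beyond the scatter) from compound 2 to compound 1 and a number 46 percentage points lower (beyond the scatter) from compound 3 to compound 4, 23 percentage points apart, beyond the scatter of two such steps For anyone planning to move this change to another core in the series, two pairs support only a cautious statement: the sign of the step held in both, while its size in one pair gave a poor guide to its size in the other.

Going by these compounds alone, these two pairs do not show what sets the size of the step, since they differ both in the carboxyphenyl group of the core and in where the methoxy enters, para to a carboxy group in compound 4 and at a different place in compound 1, and no pair here separates those two differences.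

The compounds shown leave open whether a fluorine or an amine in that same place would also leave less of the compound after incubation. They also leave open whether a longer chain in the linker would change the size of the methoxy step.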